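Phenyl for Butyl: Expected Solubility of Compound 3

This account rests on a few compounds, and the source may have more. Where it says the series, first, only, none or still open, it means among the compounds named here.

Compound 2 `CCCCNc1nc(NCc2ccccc2)nc2ccccc12` has been measured in a physicochemical assay for solubility, at pH 7.4; on this read-out higher numbers stand for higher solubility and lower numbers for lower solubility. There compound 2 reaches only a limit of <= 10000 nM, not a number. Within the data shown here, its single measured neighbour, compound 1 `CNc1nc(NCc2ccccc2)nc2ccccc12`, likewise sits at a limit, giving <= 10000 nM in this assay. The step that the two limits leave unreadable from compound 1 to compound 2 is unreadable because both ends rest on (the limit of <= 10000 nM in this assay, at which 2 of the 2 values shown sit). Compound 3 `c1ccc(CNc2nc(Nc3ccccc3)c3ccccc3n2)cc1` carries phenyl in place of butyl on a nitrogen on an aromatic ring. Among the measured compounds shown here, no measured step covers this change, and the step that the limit leaves unreadable from compound 2 to compound 3 is expected to stay within the scatter. Compound 3 is estimated at 4000 nM, in a range from 500 nM to 10000 nM, most likely reported once more only as a limit.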

Compound 3, solubility: <= 5000 nM
Compound 3 gave a limit, no number; the forecaster's own chance of this, stated with the estimate: 85%; the middle value does not contradict the limit.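

Among these compounds, compound 1, compound 2 and compound 3 are all reported only as limits in this assay, so no step between them can be read. The compounds shown leave open their actual solubility values, and whether phenyl in place of butyl changes solubility at all.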